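Removing an acetyl group from two related cyclic peptide cores

The compounds below may be only part of what the source reports. "The series", "measured", "known", "first", "only" and "open" are said of these compounds alone.

Compound 1 `CCCC[C@@H](C)C[C@@H](C)C(=O)N(C)[C@@H](C=C(C)C)C(=O)N[C@H](C(=O)N(C)[C@H](C(=O)N1C[C@@H](O)C[C@H]1C(=O)N1C(=O)C=C[C@@H]1C)C(C)C)[C@@H](C)OC(C)=O`: 37 nM
Compound 2 `CCCC[C@@H](C)C[C@@H](C)C(=O)N(C)[C@@H](C=C(C)C)C(=O)N[C@H](C(=O)N(C)[C@H](C(=O)N1C[C@@H](O)C[C@H]1C(=O)N1C(=O)C=C[C@@H]1C)C(C)C)[C@@H](C)O`: 160 nM
Compound 3 `CCCC[C@@H](C)C[C@@H](C)C(=O)N(C)[C@@H](CC(C)C)C(=O)N[C@H](C(=O)N(C)[C@H](C(=O)N1CCC[C@H]1C(=O)N1C(=O)CC[C@@H]1C)C(C)C)[C@@H](C)OC(C)=O`: 5000 nM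

All three compounds were tested in a functional assay on NCI-H460 cells (Homo sapiens) for cytotoxicity, read by MTT assay, with a stated time of 48 h; on this read-out higher numbers stand for weaker inhibition and lower numbers for stronger inhibition. Compound 1 gives 37 nM and compound 2 gives 160 nM. Compound 2 differs from compound 1 by one change, (hydrogen in place of acetyl on an oxygen on a saturated carbon), and this change produced a 4.3-fold higher number from compound 1 to compound 2 (0.64 log units; beyond the scatter).

Compound 3 gives 5000 nM in this assay, the highest number of the three. How the core of compound 3 differs from the core of compound 1 is not broken down here.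

Compound 4 `CCCC[C@@H](C)C[C@@H](C)C(=O)N(C)[C@@H](CC(C)C)C(=O)N[C@H](C(=O)N(C)[C@H](C(=O)N1CCC[C@H]1C(=O)N1C(=O)CC[C@@H]1C)C(C)C)[C@@H](C)O` has not yet been measured. Within the data shown here, it differs from compound 3 by hydrogen in place of acetyl on an oxygen on a saturated carbon, which is the same change as the one from compound 1 to compound 2, at the same kind of place. On the expectation that the change repeats its earlier effect, the step is estimated as a 4.0-fold higher number from compound 3 to compound 4 (0.60 log units; beyond the scatter), resting on the step of a 4.3-fold higher number from compound 1 to compound 2 (0.64 log units; beyond the scatter) and on the starting value of compound 3 5000 nM. Compound 4 is therefore expected to give about 20000 nM in this assay, with a likely range from 8000 nM to 50000 nM.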

Compound 4, half-maximal inhibitory concentration: > 30000 nM
Compound 4: no number, only a limit; the forecaster's own chance of this, stated with the estimate: 30%; middle value at least 1.5-fold (0.17 log units) from the limit.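

In this assay compound 4 gives > 30000 nM, which is a limit of the assay and not a number. Replacing the acetyl group with hydrogen moves the number the same way on both cores, and on the core of compound 3 this is an at least 6.0-fold higher number from compound 3 to compound 4 (0.77 log units; beyond the scatter). The direction of the change therefore carries over between these two cores, but the limit means the data do not show whether its size carries over as well: the same change on two cores in this assay, a 4.3-fold higher number (0.64 log units; beyond the scatter) from compound 1 to compound 2 and an at least 6.0-fold higher number (0.77 log units; beyond the scatter) from compound 3 to compound 4; the limit leaves it open whether they differ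

The compounds shown carry only acetyl or hydrogen on this oxygen, which leaves open how a different group there, such as a methyl ether or a longer acyl chain like butyryl, would behave on either core. Also open is which of the differences between the two cores goes with the much higher number of compound 3, as no pair shown separates those differences one at a time.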